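Swapping the Aryl Group: What to Expect for Compound 3

The source may report more compounds than this note shows. Statements on the series, on what has been measured and on what is new or still open speak of the compounds shown alone.

Compound 1 `COc1ccccc1/C=c1/[nH]c(=O)/c(=C\c2ccccc2OC)[nH]c1=O` has no result reported in a functional assay on MOLT-4 cells (Homo sapiens) for cytotoxicity, read by CCK-8 assay, with a stated time of 72 h (a lower number here means a stronger inhibitor, a higher number a weaker inhibitor), its entry reading "not determined" (no result reported). Compound 2 `C=CCn1c(=O)/c(=C\c2cc(F)ccc2C)[nH]c(=O)/c1=C\c1ccccc1OC` gives 3800 nM in this assay; this is the only number shown, so nothing can be said about how it ranks against other compounds. Compound 3 `C=CCn1c(=O)/c(=C\c2ccccc2Cl)[nH]c(=O)/c1=C\c1ccccc1OC` differs from compound 2 by 2-chlorophenyl in place of 5-fluoro-2-methylphenyl on a double-bonded chain carbon bound to an aromatic carbon. Among the compounds with values here, no measured pair shows what such a change does to potency, so no step beyond the usual scatter is expected in either direction. The step of a 1.1-fold lower number from compound 2 to compound 3 (0.04 log units; within the scatter) is therefore expected to be small. Compound 3 is estimated at 3500 nM, with a range of 1200 nM to 10000 nM.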

Compound 3, half-maximal inhibitory concentration: 4400 nM
Beside the measured number, compound 3's estimate is 1.3-fold (0.10 log units) below it; measured number inside the range.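

In this assay, within the data shown here, the change from 5-fluoro-2-methylphenyl to 2-chlorophenyl gives a 1.2-fold higher number from compound 2 to compound 3 (0.06 log units; within the scatter) as the only measured step at this place. Within the scatter, this assay does not separate these two aryl groups, even though the methyl and fluorine give way to a single chlorine. No measurement shown offers an explanation for this result.

Still open, going by these compounds, is whether a quite different group here, such as a carboxylic acid, an amine or a longer chain, would shift the number beyond the scatter. On these data alone, whether any other part of the molecule matters also remains unknown.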